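Polar Aryl Swap on a Fused Core in HT-29 Cells

The compounds below may be only part of what the source reports. "The series", "measured", "known", "first", "only" and "open" are said of these compounds alone.

Measured compounds:
compound 1 `CS(=O)(=O)c1ccc(Cc2nnc3n2N=C(c2ccccc2)CS3)cc1`: 42%
compound 2 `CS(=O)(=O)c1ccc(Cc2nnc3n2N=C(c2cc(Cl)sc2S(N)(=O)=O)CS3)cc1`: 22.8%
compound 3 `Cc1ccc(C2=Nn3c(Cc4ccc(S(C)(=O)=O)cc4)nnc3SC2)cc1`: "not active" (no number reported)

Of the compounds shown here, three sharing one core have been tested in a functional assay on HT-29 cells (Homo sapiens) for cytotoxicity, read by MTT assay, with a stated time of 48 h, tested at 12.5 uM; on this read-out higher numbers stand for a stronger effect at the one concentration tested and lower numbers for a weaker effect. Compound 1 gives 42%. Within the data shown here, compound 2 gives 22.8%, and the one step between measured compounds runs a number 19.2 percentage points lower from compound 1 to compound 2 (beyond the scatter). Compound 3 stands without a number: in this assay compound 3 is reported as "not active" (no number reported), so it cannot be placed among the others except as the weakest of the three on the record.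

Compound 4 `CS(=O)(=O)c1ccc(Cc2nnc3n2N=C(c2ccc(O)c(C(N)=O)c2)CS3)cc1` is not yet measured. It differs from compound 3 as follows: 3-carbamoyl-4-hydroxyphenyl in place of 4-methylphenyl on a carbon with a double bond to nitrogen. Among the measured compounds shown here, the only step that bears on this change is the exchange of the aryl group on the same carbon, from compound 1 to compound 2, which lowered the read-out modestly. Compound 3 begins from no measurable activity, so a sizeable rise would be needed for compound 4 to register clearly. Compound 4 is therefore expected to remain weak in this assay, estimated at 15% with a range from 0% to 35%.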

Compound 4, a percentage reported as activity, at one concentration (the size of the read-out at that concentration, not a potency): 24.8%
The estimate for compound 4 lay 9.8 percentage points below the measured number; the measured number falls inside the stated range.
By their numbers in this assay, from the lowest: compounds 2 and 4 (each within the scatter of the next); then compound 1.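

In this assay there is a number 17.2 percentage points lower from compound 1 to compound 4 (beyond the scatter) and a number 2 percentage points higher from compound 2 to compound 4 (within the scatter) so two different substituted aryl groups on the carbon with a double bond to nitrogen, 3-carbamoyl-4-hydroxyphenyl and 5-chloro-2-sulfamoylthiophen-3-yl, both stand apart from phenyl and lie within the scatter of each other. Compound 3 is reported as "not active" (no number reported) while compound 4 gives 24.8% and so registers a number where 4-methylphenyl gives none, but the steps to compound 3 cannot be read. Nothing in the data gives a reason for these differences.

Going by these compounds, it remains open whether a phenyl carrying only a hydroxyl or only a carboxamide would give the read-out of compound 4 or that of compound 1. On these data alone, it also remains open how a carboxylic acid or an amine on that phenyl would read.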